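From Benzylamino to Methoxy on the Carbonyl

This account rests on a few compounds, and the source may have more. Where it says the series, first, only, none or still open, it means among the compounds named here.

In a functional assay on A549 cells (Homo sapiens) for inhibition, read by sulforhodamine B assay, with a stated time of 72 h (a higher number here means a weaker inhibitor, a lower number a stronger inhibitor), compound 1 `Nc1sc(-c2ccc(Cl)cc2)c(-c2ccc(Cl)cc2)c1C(=O)N1CCCCC1` gives 4620 nM and compound 2 `CC1CN(C(=O)c2c(N)sc(-c3ccc(Cl)cc3)c2-c2ccc(Cl)cc2)CCN1` gives 4930 nM with a 1.1-fold higher number from compound 1 to compound 2 (0.03 log units; within the scatter) as the step. Compound 3 `Nc1sc(-c2ccc(Cl)cc2)c(-c2ccc(Cl)cc2)c1C(=O)NCc1ccccc1` stands as the weakest inhibitor of the three at 16300 nM in this assay. Compound 4 `COC(=O)c1c(N)sc(-c2ccc(Cl)cc2)c1-c1ccc(Cl)cc1` has methoxy in place of benzylamino on a carbonyl carbon and has not yet been measured. Two measured steps change the group at that place: a 3.5-fold higher number from compound 1 to compound 3 (0.55 log units; beyond the scatter) and a 3.3-fold higher number from compound 2 to compound 3 (0.52 log units; beyond the scatter) are both modest and neither brings in methoxy, so a small step, if any, toward a lower number is expected. In this assay the expected move is a 1.8-fold lower number from compound 3 to compound 4 (0.26 log units; within the scatter) by this estimate. Compound 4 is estimated at 9000 nM with 3000 nM to 28000 nM as its expected range.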

Compound 4, half-maximal inhibitory concentration: 5040 nM
Estimate against measurement, compound 4: 1.8-fold (0.25 log units) above; the range from low to high includes it.
By their numbers in this assay, from the lowest: compounds 1, 2 and 4 (each within the scatter of the next); then compound 3.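

In this assay, methoxy on the carbonyl carbon gives a 3.2-fold lower number from compound 3 to compound 4 (0.51 log units; beyond the scatter), while a 1.0-fold higher number from compound 2 to compound 4 (0.01 log units; within the scatter) and a 1.1-fold higher number from compound 1 to compound 4 (0.04 log units; within the scatter) leave it level with the two amides that carry a saturated ring. The carbonyl therefore need not carry a nitrogen group at this place, and of the four groups shown, only benzylamino stands apart. No measurement here explains why benzylamino differs. On these data alone, it also remains open whether a carboxylic acid or a longer chain such as ethoxy would stay with compound 1, compound 2 and compound 4.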